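A few compounds are considered here, and "the series" means these few. Any claim that something is new, unique, unknown or untested is made for them only; others in the source may bear on it.

Compound 1 `CNC(=O)c1ccc(-c2cnc3ncn(C(C)c4cc5cccnc5cc4F)c3n2)cc1F` and compound 2 `CC(c1cc2cccnc2cc1F)n1cnc2ncc(-c3ccc(C(N)=O)c(F)c3)nc21` share one core, while compound 3 `CNC(=O)c1ccc(/C=N/CNC(C)c2ccc3ncccc3c2)cc1F` and compound 4 `CC(NC/N=C/c1ccc(C(N)=O)c(F)c1)c1ccc2ncccc2c1` share another; the difference between the two cores is not broken down here. In a functional assay on NCI-H1993 cells (Homo sapiens) for inhibition, read by CCK-8 assay, with a stated time of 72 h (a lower number here means a stronger inhibitor, a higher number a weaker inhibitor), compound 1 gives 32.7 nM, and compound 2 gives 19.5 nM. The change between them is hydrogen in place of methyl on an amide-type nitrogen, and the step it made was a 1.7-fold lower number from compound 1 to compound 2 (0.22 log units; within the scatter). Compound 3 gives 191 nM in this assay, the highest of the three numbers and beyond the scatter from both compound 1 and compound 2. Compound 4 carries the same change relative to compound 3, (hydrogen in place of methyl on an amide-type nitrogen), at a place described in the same words as before. Among the measured compounds shown here, the only guide to what this change does is the single earlier step, a 1.7-fold lower number from compound 1 to compound 2 (0.22 log units; within the scatter), which stayed within the scatter. On that basis the step from compound 3 to compound 4 is expected to be a 1.6-fold lower number from compound 3 to compound 4 (0.20 log units; within the scatter). Compound 4 is therefore estimated to give 120 nM in this assay, most likely between 55 nM and 260 nM.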

Compound 4, half-maximal inhibitory concentration: 238 nM
For compound 4 the middle estimate is 2.0-fold (0.30 log units) below the measured one, and the stated range covers the measured number.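

In this assay, hydrogen in place of methyl on the amide-type nitrogen gives a 1.2-fold higher number from compound 3 to compound 4 (0.10 log units; within the scatter), so on this second core, as on the first, the change leaves compounds that cannot be told apart. Set side by side, the two steps point in opposite directions on paper, but they do not differ from each other: the same change on two cores in this assay, a 1.7-fold lower number (0.22 log units; within the scatter) from compound 1 to compound 2 and a 1.2-fold higher number (0.10 log units; within the scatter) from compound 3 to compound 4, 2.1-fold (0.32 log units) apart, within the scatter of two such steps. This shows that, across these two pairs, swapping methylcarbamoyl for carbamoyl carried over from one core to the other without a step beyond the scatter in this assay, but it does not show that the change has any real effect on either core, nor that the same would hold on a third core.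

The compounds shown leave open whether an ethyl group or a longer chain on that nitrogen, or a carboxylic acid or nitrile in place of the carbamoyl group, would give a step beyond the scatter. They also leave open whether the two pairs would behave alike in any other read-out.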